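Amine-end extension in the diaryl ether benzothiazole series

The source may hold more compounds than are shown below. What is called first, only, known or untested is meant among the compounds shown, and "the series" means these compounds.

Three compounds of this series carry a number in an assay on SH-SY5Y cells for inhibition of Voltage-dependent N-type calcium channel subunit alpha-1B (Homo sapiens), read by FLIPR and calcium flux, with stated times of 600 s and 300 s, in the presence of a further agent that is not named here; on this read-out lower numbers stand for stronger inhibition and higher numbers for weaker inhibition. Compound 1 `NCCCOc1ccc(CNc2nc3ccc(Oc4ccc(O)cc4)cc3s2)cc1` gives 205000 nM. Compound 2 `NCCCOc1ccc(CNc2nc3ccc(Oc4ccc(C(F)(F)F)cc4)cc3s2)cc1` gives 59000 nM, and compound 3 `CN(Cc1ccc(OCCCN)cc1)c1nc2ccc(Oc3ccc(C(F)(F)F)cc3)cc2s1` gives 283000 nM. Compound 2 therefore holds the lowest number of the three: the step of a 3.5-fold lower number from compound 1 to compound 2 (0.54 log units; beyond the scatter) sets it apart from compound 1, and the step of a 4.8-fold higher number from compound 2 to compound 3 (0.68 log units; beyond the scatter) sets it apart from compound 3. The new compound 4 `N=C(N)NCCCOc1ccc(CNc2nc3ccc(Oc4ccc(C(F)(F)F)cc4)cc3s2)cc1` is compound 2 with a group of 3 heavy atoms (1 carbon, 2 nitrogen; no ring) in place of a hydrogen atom, on an amine nitrogen. Neither measured step touches this part of the molecule: the first step changes the substituent on the distal aromatic ring, the second changes the nitrogen attached to the shared core, while the amine at the end of the chain is left as it is in both. Within the data shown here, there is thus no step in the data that bears on the change from compound 2 to compound 4, and no direction can be read from the series. The expectation is accordingly a step of a 1.2-fold lower number from compound 2 to compound 4 (0.07 log units; within the scatter) in this assay, which is not beyond the scatter, with a wide band to either side. Compound 4 is estimated at 50000 nM, within a range of 15000 nM to 180000 nM.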

Compound 4, half-maximal inhibitory concentration: 167000 nM
Estimate against measurement, compound 4: 3.3-fold (0.52 log units) below; low and high end bracket the measured number.
By their numbers in this assay, from the lowest: compound 2; then compounds 4, 1 and 3 (each within the scatter of the next).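

Among these compounds, compound 2 to compound 4 is the first step at the amine nitrogen at the end of the chain, and it shows that this position is not indifferent in this assay: the step is a 2.8-fold higher number from compound 2 to compound 4 (0.45 log units; beyond the scatter), so putting the group of 3 heavy atoms (1 carbon, 2 nitrogen) in place of a hydrogen atom there weakens inhibition. The earlier steps shown here changed only the substituent on the distal aromatic ring and the nitrogen on an aromatic ring, so this one adds a third site of the molecule at which a single change moves the number beyond the scatter, again by a modest amount. Nothing shown explains why this change at the amine nitrogen weakens inhibition.

Going by these compounds, it remains open whether smaller or differently built groups on this nitrogen, such as a methyl, two methyls or an acetyl, would keep the number of compound 2 or lower it, and whether a shorter or longer chain carrying the same amine would do so. On these data alone, it is equally open whether the same replacement would give a step of similar size on the hydroxy compound 1, since only the trifluoromethyl compound carries it here.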